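The source may hold more compounds than are shown below. What is called first, only, known or untested is meant among the compounds shown, and "the series" means these compounds.

Compound 1 `CCOC(=O)c1ccsc1NC(=O)[C@@H]1CCCN1`: 35.3 ug/mL
Compound 2 `O=C(OC1CCCCC1)c1ccsc1NC(=O)[C@@H]1CCCN1`: 92.8 ug/mL

In a functional assay on HeLa cells (Homo sapiens) for inhibition (a lower number here means a stronger inhibitor of growth, a higher number a weaker inhibitor of growth), compound 2 gives 92.8 ug/mL, the higher of the two numbers, which makes it the weaker growth inhibitor of the pair. Compound 3 `O=C(OCC(Cl)(Cl)Cl)c1ccsc1NC(=O)[C@@H]1CCCN1` is not yet measured. It differs from compound 2 in one place: 2,2,2-trichloroethyl in place of cyclohexyl on an oxygen next to a carbonyl group. In short, 2,2,2-trichloroethyl stands in place of cyclohexyl on an oxygen next to a carbonyl group.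

Among the compounds with values here, only one measured step touches this place: a 2.6-fold higher number from compound 1 to compound 2 (0.42 log units; beyond the scatter), where cyclohexyl replaced ethyl. Like the ethyl of compound 1, the new group has no ring, so removing the cyclohexyl may undo part of that modest step. On these data alone, one step is thin evidence, and chlorine is untested here, so the range stays wide. The estimated change is a 1.9-fold lower number from compound 2 to compound 3 (0.27 log units; within the scatter), a modest move towards a lower number. The expected value for compound 3 is 50 ug/mL, with an estimated range of 20 ug/mL to 120 ug/mL.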

Compound 3, concentration for 50% growth inhibition: > 250 ug/mL
Compound 3 was reported as a limit; the forecaster's own chance of this, stated with the estimate: 8%; at least 5.0-fold (0.69 log units) between middle value and limit.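

In this assay compound 3 gives > 250 ug/mL, which is a limit of the assay and not a number, and it is alone there among the compounds shown: the limit of > 250 ug/mL in this assay, at which 1 of the 3 values shown sits. Losing the ring does not by itself bring growth inhibition back, as 2,2,2-trichloroethyl has no ring, yet this change gave an at least 2.6-fold higher number from compound 2 to compound 3 (0.43 log units; beyond the scatter). Set against the ethyl of compound 1, which also has no ring, trichloromethyl in place of the methyl end gave an at least 7.0-fold higher number from compound 1 to compound 3 (0.85 log units; beyond the scatter), so this place responds to more than the presence of a ring, and compound 1 keeps the lowest number of the three.

Open, on these data alone, is how a propyl or a 2,2,2-trifluoroethyl group would read at this place, which would help separate the role of chlorine from that of chain length. As far as these compounds go, the true size of both rises also stays open, as compound 3 has only a limit.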